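Amine-bearing side chains on the cyclopropanecarboxamide series

The source may report more compounds than this note shows. Statements on the series, on what has been measured and on what is new or still open speak of the compounds shown alone.

Measured so far:
- compound 1, `CC[C@H](C)[C@@H](CN(C(=O)[C@@H]1C[C@H]1c1ccccc1)c1ccc(-c2ccccc2)cc1)NC(C)=O`: 5.8 nM
- compound 2, `CC(C)[C@H](N)CN(C(=O)[C@@H]1C[C@H]1c1ccccc1)c1ccc(-c2ccccc2)cc1`: 1.1 nM
- compound 3, `CCC(CC)C(N)CCN(C(=O)[C@@H]1C[C@H]1c1ccccc1)c1ccc(-c2ccccc2)cc1`: 2 nM

All three share one core and differ only in the side chain on the amide-type nitrogen. In a functional assay for agonist activity at G protein-coupled receptor 88 (Homo sapiens), read by HTRF and cAMP accumulation (a lower number here means that less compound is needed, a higher number that more compound is needed for the effect), compound 3 stands second highest of the three numbers; its nearest neighbour is compound 2 (a 1.8-fold higher number from compound 2 to compound 3 (0.26 log units; within the scatter)), and the step of a 2.9-fold lower number from compound 1 to compound 3 (0.46 log units; beyond the scatter) is the larger one. Among the compounds with values here, the only change beyond the scatter in this set is the loss of the acetyl group, seen in a 5.3-fold lower number from compound 1 to compound 2 (0.72 log units; beyond the scatter) and a 2.9-fold lower number from compound 1 to compound 3 (0.46 log units; beyond the scatter); shifting the free amine and its branching, as in a 1.8-fold higher number from compound 2 to compound 3 (0.26 log units; within the scatter), changed little.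

Compound 4, `CCC(C)CNCCN(C(=O)[C@@H]1C[C@H]1c1ccccc1)c1ccc(-c2ccccc2)cc1`, is not yet measured. It differs from compound 3 by (2-methylbutyl)amino in place of 1-amino-2-ethylbutyl on a saturated chain carbon, two bonds along the chain from an amide-type nitrogen. The amine thus becomes a secondary one and moves one bond along the chain, a kind of change not covered by any measured step; the free amine is kept, as in compound 2 and compound 3. No step beyond the scatter is therefore expected in this assay , though the untested shift leaves the range wide. Compound 4 is expected to give 4 nM (estimated range 1.5 nM to 12 nM). That estimate means a step of a 2.0-fold higher number from compound 3 to compound 4 (0.30 log units; within the scatter).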

Compound 4, half-maximal effective concentration: 4.7 nM
For compound 4 the middle estimate is 1.2-fold (0.07 log units) below the measured one, within the range that was stated.
By their numbers in this assay, from the lowest: compounds 2 and 3 (each within the scatter of the next); then compounds 4 and 1 (each within the scatter of the next).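

In this assay, within the data shown here, the (2-methylbutyl)amino side chain gives the first change beyond the scatter among compounds that keep a free amine: a 2.4-fold higher number from compound 3 to compound 4 (0.37 log units; beyond the scatter), and a 4.3-fold higher number from compound 2 to compound 4 (0.63 log units; beyond the scatter). A free amine on this chain is therefore not enough on its own to hold the number at the level of compound 2 and compound 3, and a 1.2-fold lower number from compound 1 to compound 4 (0.09 log units; within the scatter) leaves compound 4 within the scatter of the acetamide compound 1. Nothing available accounts for this result.

The change to compound 4 alters the amine type, its place on the chain and the alkyl branching together, and the compounds shown do not separate these contributions. From the compounds shown here alone, a tertiary amine such as dimethylamino, or a hydroxyl group in place of the amine, remains open at this position.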